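Changing the ring on the amide nitrogen of compound 2

A few compounds are considered here, and "the series" means these few. Any claim that something is new, unique, unknown or untested is made for them only; others in the source may bear on it.

Measured so far:
Compound 1 `NCc1ccc(C(=O)Nc2ccncc2F)cc1-c1cccc(C(=O)Nc2cccc(CC(=O)O)c2)c1`: 1.5 nM
Compound 2 `NCc1ccc(C(=O)Nc2ccncc2F)cc1-c1cccc(C(=O)Nc2ccc(CC(=O)O)cc2)c1`: 1.8 nM

In an assay on cells for inhibition of Rho-associated protein kinase 2 (Homo sapiens), read by radiometric assay and 33P incorporation, in the presence of a further agent that is not named here (a lower number here means a stronger inhibitor, a higher number a weaker inhibitor), compound 1 gives 1.5 nM and compound 2 gives 1.8 nM. Among the measured compounds shown here, the single step of a 1.2-fold higher number from compound 1 to compound 2 (0.08 log units; within the scatter) leaves the two compounds indistinguishable on these numbers. Compound 3 `COC(=O)c1cccc(NC(=O)c2cccc(-c3cc(C(=O)Nc4ccncc4F)ccc3CN)c2)c1F` is not yet measured and differs from compound 2 in one place: 2-fluoro-3-(methoxycarbonyl)phenyl in place of 4-(carboxymethyl)phenyl on an amide-type nitrogen. That step moved a carboxymethyl group within the ring and barely registered, but nothing measured covers exchanging it for a fluorine and a methoxycarbonyl group. A modest weakening is expected, a 2.2-fold higher number from compound 2 to compound 3 (0.35 log units; beyond the scatter). Compound 3 is therefore estimated at 4 nM, within 1.5 nM to 12 nM.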

Compound 3, half-maximal inhibitory concentration: 1.2 nM
The estimate for compound 3 lay 3.3-fold (0.52 log units) above the measured number; measured number outside the range, below it.
By their numbers in this assay, from the lowest: compounds 3, 1 and 2 (each within the scatter of the next).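

In this assay, the two new steps read a 1.5-fold lower number from compound 2 to compound 3 (0.18 log units; within the scatter) and a 1.3-fold lower number from compound 1 to compound 3 (0.10 log units; within the scatter), so neither separates the compounds. This position on the amide-type nitrogen therefore holds 2-fluoro-3-(methoxycarbonyl)phenyl, with no hydrogen-bond donor, and either carboxymethyl-bearing phenyl ring without a difference these numbers can resolve. No evidence at hand accounts for this result. Still open, as far as these compounds go, is what the fluorine and the methoxycarbonyl group each contribute alone, and whether an amine or a longer chain on this ring would give a similar number.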